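A few compounds are considered here, and "the series" means these few. Any claim that something is new, unique, unknown or untested is made for them only; others in the source may bear on it.

Working notes on the series. Compound 1 `Cn1cncc1CN1CC(N(CC2CCN(C(=O)CC(F)(F)F)CC2)S(=O)(=O)c2ccccn2)Cc2cc(C#N)ccc21` and compound 2 `Cn1cncc1CN1CC(N(CC2CCN(C(=O)C3CC3)CC2)S(=O)(=O)c2ccccn2)Cc2cc(C#N)ccc21` share one core and differ only at the carbonyl carbon of the piperidine amide. In an ADME assay on Caco-2 cells (Homo sapiens) for permeability, in the apical to basolateral direction (on this read-out lower numbers stand for lower permeability and higher numbers for higher permeability), compound 1 gives 0.5 10^-6 cm/s, and in this assay compound 2 gives 0.5 10^-6 cm/s. Among the compounds with values here, the step of no change at the digits printed from compound 1 to compound 2 (within the scatter) therefore shows that exchanging the group on this carbonyl carbon left the read-out unchanged, and compound 2 stands level with compound 1 on the numbers so far.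

Compound 3 `Cn1cncc1CN1CC(N(CC2CCN(C(=O)OC(C)(C)C)CC2)S(=O)(=O)c2ccccn2)Cc2cc(C#N)ccc21` is the next member and has not yet been measured in this assay. Its difference from compound 2 is tert-butoxy in place of cyclopropyl on a carbonyl carbon. Within the data shown here, the only step that bears on this position is no change at the digits printed from compound 1 to compound 2 (within the scatter), which was flat, and nothing measured so far separates a carbon-only substituent from an oxygen-linked one on this carbonyl. The expected step of a 1.2-fold higher number from compound 2 to compound 3 (0.08 log units; within the scatter) is accordingly small and not beyond the scatter, with no firm direction. The expected value for compound 3 in this assay is 0.6 10^-6 cm/s, within a range of 0.3 10^-6 cm/s to 1.5 10^-6 cm/s, and the measurement is awaited.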

Compound 3, apparent permeability: 15.5 10^-6 cm/s
Beside the measured number, compound 3's estimate is 26-fold (1.41 log units) below it, outside the stated range (above it).
By their numbers in this assay, from the lowest: compounds 1 and 2 (each within the scatter of the next); then compound 3.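

In this assay the substituent on this carbonyl carbon, whose other neighbour is the amide-type ring nitrogen, can move the read-out strongly: there is a 31-fold higher number from compound 2 to compound 3 (1.49 log units; beyond the scatter) when tert-butoxy replaces cyclopropyl and a 31-fold higher number from compound 1 to compound 3 (1.49 log units; beyond the scatter) when tert-butoxy replaces 2,2,2-trifluoroethyl. The flat result from compound 1 and compound 2 therefore holds only for that pair, and it does not extend to the whole position, since tert-butoxy is the only group shown here that places an oxygen on the carbonyl carbon and the only one that gives a large step. No data shown here give a reason for this step.

The compounds shown do not separate the oxygen link from the branched four-carbon unit, as both enter together in tert-butoxy; a tert-butyl group directly on the carbonyl carbon and a methoxy group at the same place would pull these two apart. Also open, on these data alone, is whether the same step would appear with the pyridine-free sulfonyl variants of the core or with an amine on this carbonyl carbon.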